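Dropping the nitrile from compound 2

The compounds below may be only part of what the source reports. "The series", "measured", "known", "first", "only" and "open" are said of these compounds alone.

Compound 1 `Cc1nn(-c2nc(-c3ccc(Cl)c(Cl)c3)c(SC(C)C)s2)c(C(=O)O)c1-c1cccc(F)c1`: 900 nM
Compound 2 `COc1cc(C#N)cc(-c2c(C)nn(-c3nc(-c4ccc(Cl)c(Cl)c4)c(SC(C)C)s3)c2C(=O)O)c1`: 5200 nM

Of the compounds shown here, two have been measured in a functional assay on BJAB cells (Homo sapiens) for antiproliferative activity, with a stated time of 4 days; on this read-out lower numbers stand for an effect already at smaller amounts and higher numbers for an effect only at larger amounts of compound. Compound 1 gives 900 nM in this assay. Within the data shown here, compound 2 gives 5200 nM in this assay, the highest of the two numbers; its nearest neighbour is compound 1, and the single step recorded, a 5.8-fold higher number from compound 1 to compound 2 (0.76 log units; beyond the scatter), is beyond the scatter.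

Compound 3 `COc1cccc(-c2c(C)nn(-c3nc(-c4ccc(Cl)c(Cl)c4)c(SC(C)C)s3)c2C(=O)O)c1` is not yet measured. It differs from compound 2 in one place: hydrogen in place of cyano on an aromatic carbon. The change removes part of what was added in the step from compound 1 to compound 2, leaving the methoxy group in place, so compound 3 sits between compound 1 and compound 2 in structure. Among the measured compounds shown here, no measured step isolates the cyano group alone, and no step covers fluorine against methoxy, so the expectation is weaker than a direct comparison would allow. Because a 5.8-fold higher number from compound 1 to compound 2 (0.76 log units; beyond the scatter) was the only loss recorded and it came with both new groups together, compound 3 is expected to move back toward compound 1, by a modest step of a 2.4-fold lower number from compound 2 to compound 3 (0.37 log units; beyond the scatter). The estimate for compound 3 is 2200 nM, within a range of 800 nM to 6000 nM.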

Compound 3, half-maximal effective concentration: 14000 nM
For compound 3 the middle estimate is 6.4-fold (0.80 log units) below the measured one; measured number above the stated range.
By their numbers in this assay, from the lowest: compound 1; then compound 2; then compound 3.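

Removing the nitrile did not move the number back toward compound 1: in this assay the change gave a 2.7-fold higher number from compound 2 to compound 3 (0.43 log units; beyond the scatter), so with the methoxy group in place, the compound carrying the nitrile has the lower number of the pair. Among these compounds, the earlier step, a 5.8-fold higher number from compound 1 to compound 2 (0.76 log units; beyond the scatter), had combined two changes, and the new comparison separates them: methoxy in place of fluoro alone gives a 16-fold higher number from compound 1 to compound 3 (1.19 log units; beyond the scatter), a larger rise than the one seen with both groups present, so the rise follows the methoxy group and the nitrile reduces it rather than adds to it. This holds for one pair of compounds on one ring, and nothing measured on any property of these groups accounts for it.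

The compounds shown leave open whether a nitrile would lower the number in the same way with fluorine on the ring instead of the methoxy group, as that pair is not among them. They also leave open how the methoxy group compares with plain hydrogen, a hydroxyl group, an amine or a longer ethoxy chain on this ring.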